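The source may hold more compounds than are shown below. What is called first, only, known or untested is meant among the compounds shown, and "the series" means these compounds.

In a functional assay on HepG2 cells (Homo sapiens) for antiproliferative activity, read by MTT assay (on this read-out higher numbers stand for weaker inhibition and lower numbers for stronger inhibition), compound 1 (`Cc1c(-n2cc(COc3ccc(/C=C/C(=O)c4cc5c(cc4O)OC(C)(C)CC5)cc3)nn2)cccc1[N+](=O)[O-]`) gives 109000 nM and stands within the scatter of both other measured compounds. Compound 2 (`CC1(C)CCc2c(ccc(C(=O)/C=C/c3ccc(OCc4cn(-c5ccc(Cl)cc5)nn4)cc3)c2O)O1`) gives 102000 nM and compound 3 (`CC1(C)CCc2c(ccc(C(=O)/C=C/c3ccc(OCc4cn(-c5ccc(Br)cc5)nn4)cc3)c2O)O1`) gives 136000 nM so no order among the three can be read.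

Compound 4 (`CC1(C)CCc2cc(C(=O)/C=C/c3ccc(OCc4cn(Cc5ccc([N+](=O)[O-])cc5)nn4)cc3)c(O)cc2O1`) keeps the core of compound 1 and carries 4-nitrobenzyl in place of 2-methyl-3-nitrophenyl on an aromatic nitrogen. Among the measured compounds shown here, the only measured step is a 1.3-fold higher number from compound 2 to compound 3 (0.12 log units; within the scatter) for bromo in place of chloro on an aromatic carbon. For the measured compounds named here, that is a different change at a different place, so it bears on this replacement only weakly, and no measured step covers the replacement itself.

The expectation therefore rests mainly on compound 1 at 109000 nM and is for no step beyond the scatter, in either direction. The estimated step is a 1.1-fold lower number from compound 1 to compound 4 (0.04 log units; within the scatter) and is expected to stay within the scatter. For compound 4 the estimate is 100000 nM with an expected range from 45000 nM to 220000 nM as a working figure.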

Compound 4, half-maximal inhibitory concentration: 109000 nM
Compound 4: the middle estimate sits 1.1-fold (0.04 log units) below what was measured; low and high end bracket the measured number.
By their numbers in this assay, from the lowest: compounds 2, 1, 4 and 3 (each within the scatter of the next).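

In this assay, putting 4-nitrobenzyl in place of 2-methyl-3-nitrophenyl on the aromatic nitrogen gives no change at the digits printed from compound 1 to compound 4 (within the scatter), the first step measured for a change of the whole group at this position rather than of one halogen on it. The two groups hold the same atoms joined differently, and this read-out does not separate them, so this replacement on the five-membered aromatic ring with 3 nitrogen leaves the antiproliferative reading where it was. No available evidence accounts for this result.

The compounds shown leave open whether any group on this nitrogen can move the number beyond the scatter. An amine, a carboxylic acid or a longer chain in this place would test that, and how each would read remains an open question for the series.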